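This account rests on a few compounds, and the source may have more. Where it says the series, first, only, none or still open, it means among the compounds named here.

Measured so far, in a functional assay on HepG2 cells (Homo sapiens) for cytotoxicity, read by MTT assay, with a stated time of 24 h; a lower number here means a stronger inhibitor, a higher number a weaker inhibitor:

compound 1 `Cc1cc(-c2nc3cc(F)ccc3o2)ccc1NC(=O)CCl` gives 16600 nM
compound 2 `Cc1cc(-c2nc3ccccc3o2)ccc1NC(=O)CN1CCN(CCCN(C)C)CC1` gives 2160 nM
compound 3 `Cc1cc(-c2nc3ccccc3o2)ccc1NC(=O)CCl` gives 14800 nM

Compound 3 and compound 1 share a core and differ only in fluoro in place of hydrogen on an aromatic carbon. The step of a 1.1-fold higher number from compound 3 to compound 1 (0.05 log units; within the scatter) lies within the scatter, so the two numbers cannot be ordered. Compound 2 carries a different chain on the amide; how its core differs from that of compound 3 is not broken down here. Compound 2 gives the lowest of the three numbers, and both gaps to it lie beyond the scatter.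

Compound 4 `Cc1cc(-c2nc3cc(F)ccc3o2)ccc1NC(=O)CN1CCN(CCCN(C)C)CC1` has not yet been measured in this assay. It differs from compound 2 by fluoro in place of hydrogen on an aromatic carbon, the same change, at the same place, that leads from compound 3 to compound 1. Given that the earlier step of a 1.1-fold higher number from compound 3 to compound 1 (0.05 log units; within the scatter) stayed within the scatter, the expected change is a 1.1-fold higher number from compound 2 to compound 4 (0.05 log units; within the scatter). Among the compounds with values here, this rests on a single pair; no other compound in the set tests the change. For compound 4 the estimate in this assay is 2400 nM, with a likely range from 1200 nM to 5000 nM.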

Compound 4, half-maximal inhibitory concentration: 7150 nM
Compound 4: the middle estimate sits 3.0-fold (0.47 log units) below what was measured; measured number outside the range, above it.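

In this assay, fluoro in place of hydrogen, which turns 1,3-benzoxazol-2-yl into 5-fluoro-1,3-benzoxazol-2-yl, gives a 3.3-fold higher number from compound 2 to compound 4 (0.52 log units; beyond the scatter). The size of this step did not carry over from one core to the other, so in this series a result for this change on the core of compound 3 cannot simply be transferred to the core of compound 2: the same change on two cores in this assay, a 1.1-fold higher number (0.05 log units; within the scatter) from compound 3 to compound 1 and a 3.3-fold higher number (0.52 log units; beyond the scatter) from compound 2 to compound 4, 3.0-fold (0.47 log units) apart, beyond the scatter of two such steps. Within the data shown here, these two pairs show only that the step differs between these two cores; they do not show which feature of the chain on the amide goes with the difference, nor what size the step would take on a third core.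

From the compounds shown here alone, whether a nitrile or a methoxy group at the same place would follow fluoro on either core remains open. Also open, going by these compounds, is how the fluoro step runs on a core carrying a shorter amine chain or a carboxylic acid on the amide.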